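A few compounds are considered here, and "the series" means these few. Any claim that something is new, unique, unknown or untested is made for them only; others in the source may bear on it.

In a physicochemical assay for lipophilicity (on this read-out higher numbers stand for higher lipophilicity and lower numbers for lower lipophilicity), only compound 1 (`O=C(O)c1cncc(C2=C(c3cc(C(F)(F)F)ccc3OCc3ccccc3)CCC2)c1`) has a number, and compound 1 gives 2.7. Compound 2 (`O=C(O)c1cc(C2=C(c3cc(Cl)ccc3OCc3ccccc3)CCC2)cnn1`) has no number in this assay, its entry reading "not determined" (no result reported). Compound 3 (`O=C(O)c1cc(C2=C(c3cc(C(F)(F)F)ccc3OCc3ccccc3)CCC2)ccn1`) likewise has no number, its entry reading "not determined" (no result reported). Compound 4 (`O=C(O)c1cc(C2=C(c3cc(Cl)ccc3OCc3ccccc3)CCC2)ncn1`) is the unmeasured partner of compound 2, and the change is 6-carboxypyrimidin-4-yl in place of 6-carboxypyridazin-4-yl on a double-bonded ring carbon. For the measured compounds named here, with no measured pair to lean on, the step from compound 2 to compound 4 in this assay is expected to be small and upward, near or just beyond the scatter. Compound 4 is estimated at 2.1, within a range from 1.5 to 2.7.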

Compound 4, distribution coefficient: 1.2
Beside the measured number, compound 4's estimate is 0.90 log units above it; the whole stated range lies above it.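

No step can be read between compound 2 and compound 4 in this assay. The compounds shown leave open what 6-carboxypyrimidin-4-yl in place of 6-carboxypyridazin-4-yl does in this assay. Nothing shown bears on the value of compound 4.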